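Terminal Group Swap at the Amide-Type Nitrogen

The source may report more compounds than this note shows. Statements on the series, on what has been measured and on what is new or still open speak of the compounds shown alone.

Three analogues share one core and differ only in the group on an amide-type nitrogen. Compound 1 `O=C(Nc1cccc(CNc2nccnc2Cl)c1)Nc1cccc2ccccc12` gives 32700 nM in a functional assay on MGC-803 cells (Homo sapiens) for antiproliferative activity, read by MTT assay, with a stated time of 48 h; on this read-out higher numbers stand for weaker inhibition and lower numbers for stronger inhibition. Compound 2 `CCOc1ccc(NC(=O)Nc2cccc(CNc3nccnc3Cl)c2)cc1` gives 7240 nM in this assay, and compound 3 `CCc1ccc(NC(=O)Nc2cccc(CNc3nccnc3Cl)c2)c(CC)c1` gives 6130 nM. Compound 2 stands second highest of the three numbers; its gap to compound 3 is within the scatter, whereas compound 1 lies beyond it with the higher number. Compound 4 `O=C(Nc1cccc(CNc2nccnc2Cl)c1)NC1CCCC1` is not yet measured. Its change from compound 2: cyclopentyl in place of 4-ethoxyphenyl on an amide-type nitrogen. Among the compounds with values here, no measured pair mirrors this change, so the step has no precedent in this set. A modest rise in the number, beyond the scatter, is expected, a 1.8-fold higher number from compound 2 to compound 4 (0.25 log units; within the scatter). Compound 4 is therefore estimated at 13000 nM, between 4500 nM and 40000 nM.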

Compound 4, half-maximal inhibitory concentration: 23400 nM
Compound 4: the middle estimate sits 1.8-fold (0.26 log units) below what was measured, within the range that was stated.
By their numbers in this assay, from the lowest: compounds 3 and 2 (each within the scatter of the next); then compounds 4 and 1 (each within the scatter of the next).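

On the amide-type nitrogen, cyclopentyl in place of 4-ethoxyphenyl gives a 3.2-fold higher number from compound 2 to compound 4 (0.51 log units; beyond the scatter) in this assay and this step lies beyond the scatter. Within the data shown here, compound 4 is the first reading here of a non-aromatic ring of carbon only, and it shows that this terminal group does not retain the level of compound 2. The data at hand give no evidence for the cause of this step.

Open, going by these compounds, is whether cyclohexyl or a longer chain such as n-butyl would behave like cyclopentyl on this nitrogen. Also open, on these data alone, is whether unsubstituted phenyl would stay near compound 2, which would separate the aromatic ring from the ethoxy group.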